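Hydantoin hydroxamates: pyridyl cap isomer at compound 4

The source may hold more compounds than are shown below. What is called first, only, known or untested is meant among the compounds shown, and "the series" means these compounds.

Three hydantoin-linked benzohydroxamic acids have numbers in an assay on isolated protein for inhibition of protein deacetylase HDAC6 (Homo sapiens), read by fluorescence, with stated times of 10 min and 2 h; a higher number here means a weaker inhibitor, a lower number a stronger inhibitor. Compound 1 `CC(C)(C)c1ccc(CN2CC(=O)N(Cc3ccc(C(=O)NO)cc3)C2=O)cc1` gives 40.7 nM in this assay, compound 2 `Cc1ccc(CC2(c3ccccc3)NC(=O)N(Cc3ccc(C(=O)NO)cc3)C2=O)cc1` gives 82.4 nM, and compound 3 `O=C(NO)c1ccc(CN2C(=O)C(Cc3ccccc3)N(Cc3ccccn3)C2=O)cc1` gives 4.8 nM. Compound 3 holds the lowest number of the three; its nearest neighbour is compound 1, whose number is higher by a margin beyond the usual scatter, and compound 2 stands furthest from it, also beyond the scatter. Among the compounds with values here, no pair of measured compounds differs in a single place, so no measured step is available to carry forward.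

Compound 4 `O=C(NO)c1ccc(CN2C(=O)C(Cc3ccccc3)N(Cc3ccncc3)C2=O)cc1` is the next entry. It differs from compound 3 in one respect: pyridin-4-yl in place of pyridin-2-yl on a saturated chain carbon bound to an amide-type nitrogen in a ring. The cap is otherwise unchanged, as are the benzyl substituent on the shared core and the hydroxamic acid.

With no measured step of this kind in the series, the expectation rests on the value of compound 3 alone. A change of ring-nitrogen position within the same cap is expected to move this assay little, most likely within the scatter or a small step towards a higher number. Compound 4 is therefore estimated at 7 nM in this assay, with a range from 2.5 nM to 20 nM; the step of a 1.5-fold higher number from compound 3 to compound 4 (0.16 log units; within the scatter) is the expected outcome.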

Compound 4, half-maximal inhibitory concentration: 13.9 nM
Estimate against measurement, compound 4: 2.0-fold (0.30 log units) below, and the stated range covers the measured number.
By their numbers in this assay, from the lowest: compound 3; then compound 4; then compound 1; then compound 2.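

In this assay the series now has its first step in a single place, and it reads a 2.9-fold higher number from compound 3 to compound 4 (0.46 log units; beyond the scatter) for pyridin-4-yl in place of pyridin-2-yl on a saturated chain carbon bound to an amide-type nitrogen in a ring. The two caps carry the same atoms and the same counts of donors and acceptors, so moving the ring nitrogen with no change in composition is enough to shift the number beyond the scatter, and this position responds to the isomer swap. No measurement at hand bears on what lies behind this step.

From the compounds shown here alone, whether pyridin-3-yl at the same place would read nearer compound 3 or compound 4 stays open, as does whether the ring nitrogen is needed at all, a question that phenyl on the same chain carbon would address. Also open, going by these compounds, is whether the step persists when the pyridine ring carries a further group such as methoxy or dimethylamino, or when the benzyl substituent on the shared core is replaced by a longer chain such as 2-phenylethyl.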